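A few compounds are considered here, and "the series" means these few. Any claim that something is new, unique, unknown or untested is made for them only; others in the source may bear on it.

Of the compounds shown here, three sharing one core have been measured in a physicochemical assay for lipophilicity, read by LC-MS, in phosphate buffer, measured as octanol-water partition, with a stated time of 30 min, at pH 7.4, tested at 200 mM; on this read-out higher numbers stand for higher lipophilicity and lower numbers for lower lipophilicity. Compound 1 `Cn1c(COc2cccc(C(=O)O)c2)nc2ccc(Oc3cc(Cl)ccn3)cc21` gives 1.2, compound 2 `Cc1cccnc1Oc1ccc2nc(COc3cccc(C(=O)O)c3)n(C)c2c1` gives 0.9, and compound 3 `Cc1cc(F)cnc1Oc1ccc2nc(COc3cccc(C(=O)O)c3)n(C)c2c1` gives 1.1. On the numbers alone compound 3 is the second highest of the three, though its gaps to compound 1 and to compound 2 both lie within the scatter. Compound 4 `Cc1cc(Cl)cnc1Oc1ccc2nc(COc3cccc(C(=O)O)c3)n(C)c2c1` differs from compound 3 by chloro in place of fluoro on an aromatic carbon. The measured step that bears most directly is a number 0.20 log units higher from compound 2 to compound 3 (within the scatter), where a halogen entered the same ring; the step of a number 0.30 log units lower from compound 1 to compound 2 (within the scatter) exchanges the whole ring and bears only loosely. For compound 4 a modest increase is therefore expected, a number 0.40 log units higher from compound 3 to compound 4 (beyond the scatter), perhaps just beyond the scatter. The estimate for compound 4 in this assay is 1.5, ranging from 1.1 to 1.9.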

Compound 4, distribution coefficient: 1.8
For compound 4 the middle estimate is 0.30 log units below the measured one; the measured number falls inside the stated range.
By their numbers in this assay, from the lowest: compounds 2, 3 and 1 (each within the scatter of the next); then compound 4.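

In this assay, the choice of halogen on this ring carbon matters: chloro in place of fluoro gives a number 0.70 log units higher from compound 3 to compound 4 (beyond the scatter), whereas the earlier fluoro in place of hydrogen stayed within the scatter. Chloro in place of hydrogen gives a number 0.90 log units higher from compound 2 to compound 4 (beyond the scatter), the first change at this position to move the number beyond the scatter. Two chlorinated rings are not interchangeable either, since exchanging one for the other gives a number 0.60 log units higher from compound 1 to compound 4 (beyond the scatter).

No measurement shown explains these steps. Going by these compounds, whether bromo, trifluoromethyl or a nitrile on this carbon would raise the number further stays open.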